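The compounds below may be only part of what the source reports. "The series", "measured", "known", "first", "only" and "open" are said of these compounds alone.

Compound 1 `Cc1cccc(/C(N)=N/NC(=S)N2CCCCC2)n1` gives 85.7% in a functional assay on A-375 cells (Homo sapiens) for cytotoxicity, read by MTT assay, with a stated time of 72 h, tested at 100 uM; on this read-out higher numbers stand for more inhibition of growth at the one concentration tested and lower numbers for less inhibition of growth. Compound 2 `N/C(=N\NC(=S)N1CCN(c2ccccn2)CC1)c1ccc(F)cn1` gives 76.2% in this assay.

Compound 1 carries the number at the top of these two, but the gap to compound 2 lies within the scatter, so the two readings cannot be told apart. Among the compounds with values here, no pair of measured compounds differs in a single place, so the two measured numbers give no step on which to lean.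

Compound 3 `Cc1cccc(/C(N)=N/NC(=S)N2CCCC2)n1` differs from compound 1 in one place: pyrrolidin-1-yl in place of piperidin-1-yl on a thiocarbonyl carbon. Nothing measured here tells how the size of this ring bears on growth inhibition in this assay, so an outcome close to that of compound 1 is expected, with any step staying within the scatter or at most slightly below it. The step of a number 5.7 percentage points lower from compound 1 to compound 3 (within the scatter) is expected to be small and slightly downward. Compound 3 is thus estimated at 80%, in a range from 62% to 94%.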

Compound 3, percent growth inhibition at one concentration: 66.3%
The estimate for compound 3 lay 13.7 percentage points above the measured number, within the range that was stated.
By their numbers in this assay, from the lowest: compounds 3, 2 and 1 (each within the scatter of the next, the first and the last beyond it).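

In this assay, the thiocarbonyl carbon proves sensitive to the size of the ring it carries: exchanging piperidin-1-yl for pyrrolidin-1-yl gives a number 19.4 percentage points lower from compound 1 to compound 3 (beyond the scatter), a modest step. Within the data shown here, this is the first measured single change, and it shows that a six-membered and a five-membered non-aromatic ring, both without hydrogen-bond donors or acceptors and without net charge, are not interchangeable at this place. Nothing available explains why the smaller ring goes with less growth inhibition.

The compounds shown leave open whether azepan-1-yl, a larger ring, would continue this trend or reverse it. They also do not tell whether morpholin-4-yl or an open-chain diethylamino group on the same carbon would match piperidin-1-yl.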